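The source may hold more compounds than are shown below. What is called first, only, known or untested is meant among the compounds shown, and "the series" means these compounds.

Measured so far:
- compound 1 `COc1cccc(-c2nc(N)nc(NCc3ccccc3)n2)c1CO` gives 4.16 in a functional assay on cells for positive allosteric modulation of G-protein coupled receptor 68 (Homo sapiens), read by a luciferase reporter and cAMP accumulation, with a stated time of 30 min, at pH 6.8 and pH 8.3, in the presence of a further agent that is not named here; a higher number here means a more potent compound, by a factor of ten per unit of this negative logarithm, a lower number a less potent compound
- compound 2 `CCOc1ccc(-c2nc(N)nc(NCc3ccccc3)n2)c(CO)c1` gives 4.37 in this assay
- compound 3 `Nc1nc(NCc2ccccc2F)nc(-c2ccccc2CO)n1` gives 4.27 in this assay

The three measured compounds fall close together in this assay. Compound 3 stands second highest of the three numbers; compound 2 is the nearest neighbour and compound 1 the furthest, and both gaps lie within the usual scatter of repeated measurements. For the measured compounds named here, nothing among the measured compounds therefore separates one from another with confidence, and no pair that differs in only one place has been measured, so no step size is established for any single change.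

Compound 4 `Nc1nc(NCc2ccc(F)cc2)nc(-c2ccccc2CO)n1` is the next compound. It differs from compound 3 in one place: 4-fluorophenyl in place of 2-fluorophenyl on a saturated chain carbon bound to a nitrogen on an aromatic ring. The two compounds contain the same atoms, joined differently.

Going by the values given here, no measured pair informs this change directly. Given that all three measured values sit in a narrow band, the expectation for compound 4 is a step of no size beyond the scatter, in either direction: the expected step from compound 3 to compound 4 is a number 0.02 log units lower from compound 3 to compound 4 (within the scatter). Compound 4 is estimated at 4.25 in this assay, with a range from 3.85 to 4.65.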

Compound 4, negative logarithm of the antagonist equilibrium constant: 3.97
Compound 4: middle estimate off by 0.28 log units, on the high side, and the stated range covers the measured number.
By their numbers in this assay, from the lowest: compounds 4, 1, 3 and 2 (each within the scatter of the next, the first and the last beyond it).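

For the compounds shown here, compounds 3 and 4 form the first pair that differs in one place, and so give the first step size for any single change: in this assay, 4-fluorophenyl in place of 2-fluorophenyl on a saturated chain carbon bound to a nitrogen on an aromatic ring is a number 0.30 log units lower from compound 3 to compound 4 (within the scatter). With the same atoms joined differently, this step does not establish that the place of the fluorine on this phenyl ring matters in this series, although a real difference of this size is not excluded by a single pair. No available evidence bears on the size of this step.

This one pair leaves open how far the result extends to other groups at this place, such as a chlorophenyl, a methoxyphenyl, a pyridyl or a cyclohexyl ring, any of which could give a step beyond the scatter. It also leaves open whether the same exchange of 2-fluorophenyl for 4-fluorophenyl would give a step of similar size on the cores of compound 1 and compound 2, which carry other groups on their second aromatic ring.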